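From acetylcarbonyl to (2-methylphenyl)sulfonyl: a cytotoxicity outlook

This account rests on a few compounds, and the source may have more. Where it says the series, first, only, none or still open, it means among the compounds named here.

Compound 1, `COc1ccc([C@H]2CC(=O)N(Cc3cccc(C#N)c3)C2)cc1OC1CCCC1`, in a functional assay on HEK293 cells (Homo sapiens) for cytotoxicity (on this read-out lower numbers stand for higher toxicity in this test and higher numbers for lower toxicity in this test), gives > 10000 nM, which is a limit of the assay rather than a number.
Compound 2, `COc1ccc([C@H]2CC(=O)N(c3cccc([S+](C)[O-])c3)C2)cc1OC1CCCC1`, in this assay gives > 10000 nM, again only a limit.
Compound 3, `COc1ccc([C@H]2CC(=O)N(c3cccc(NC(=O)C(C)=O)c3)C2)cc1OC1CCCC1`, in this assay gives > 10000 nM, also a limit.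

Compound 3 therefore stands where every measured compound here stands: at the limit, with no number of its own. The step that the two limits leave unreadable from compound 1 to compound 2 and the step that the two limits leave unreadable from compound 2 to compound 3 give no size, because the limit of > 10000 nM in this assay, at which 3 of the 3 values shown sit, means both ends of each step are limits.

Compound 4, `COc1ccc([C@H]2CC(=O)N(c3cccc(NS(=O)(=O)c4ccccc4C)c3)C2)cc1OC1CCCC1`, differs from compound 3 in one place: (2-methylphenyl)sulfonyl in place of acetylcarbonyl on a nitrogen on an aromatic ring. Among the compounds with values here, the measured steps that touch this part of the shared core, those into and out of compound 3, bear on the change only in the sense that they show no toxicity appearing anywhere so far. No readable step exists that would point to a gain or loss.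

The expectation for compound 4 is that a step that the limit leaves unreadable from compound 3 to compound 4 in this assay is nothing beyond the scatter, with the readout most likely again a limit. The estimate for compound 4 is 15000 nM, with a range from 5000 nM to 50000 nM.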

Compound 4, half-maximal cytotoxic concentration: > 10000 nM
Compound 4 gave a limit, no number; the forecaster's own chance of this, stated with the estimate: 80%; the middle value does not contradict the limit.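

No step can be read from compound 3 to compound 4 or from compound 2 to compound 4, because both ends of each step are limits and not numbers: the limit of > 10000 nM in this assay, at which 4 of the 4 values shown sit. The compounds shown leave open whether any change to the shared core would give a measurable number in this assay, and how large that step would be.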